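The compounds below may be only part of what the source reports. "The series", "measured", "known", "first", "only" and "open" are said of these compounds alone.

In a functional assay on GTL 16 cells for antiproliferative activity against GTL 16 cell line (Homo sapiens), read by CCK-8 assay, with a stated time of 72 h (on this read-out lower numbers stand for stronger inhibition and higher numbers for weaker inhibition), the two measured compounds give the following numbers.

Compound 1 `Cc1ccccc1C(=O)Nc1cccc(-c2oc3cc(-c4ccc(F)cc4)ccc3c(=O)c2O)c1` gives 24800 nM.
Compound 2 `Cc1cc(C(=O)Nc2cccc(-c3oc4cc(-c5ccc(F)cc5)ccc4c(=O)c3O)c2)ccc1F` gives 12100 nM.

For the measured compounds named here, compound 2 therefore holds the lowest of the two numbers, and its only neighbour is compound 1; the single measured step, a 2.0-fold lower number from compound 1 to compound 2 (0.31 log units; beyond the scatter), is a modest one, yet it lies beyond the scatter.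

Compound 3 `CCCc1ccc(C(=O)Nc2cccc(-c3oc4cc(-c5ccc(F)cc5)ccc4c(=O)c3O)c2)cc1` is not yet measured. It differs from compound 2 in one place: 4-propylphenyl in place of 4-fluoro-3-methylphenyl on a carbonyl carbon. Going by the values given here, the one step that bears on this, the exchange of aryl groups on the same carbonyl carbon from compound 1 to compound 2, was modest in size, and no measured step exchanges a fluorine-bearing ring for a propyl-bearing one, so there is nothing to suggest a large move in either direction. The step from compound 2 to compound 3 in this assay is thus expected to be small, a 1.2-fold lower number from compound 2 to compound 3 (0.08 log units; within the scatter), and not clearly beyond the scatter. For compound 3 the estimate in this assay is 10000 nM, with a range from 4000 nM to 30000 nM.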

Compound 3, half-maximal inhibitory concentration: 20400 nM
Beside the measured number, compound 3's estimate is 2.0-fold (0.31 log units) below it; the range from low to high includes it.
By their numbers in this assay, from the lowest: compounds 2, 3 and 1 (each within the scatter of the next, the first and the last beyond it).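

In this assay, 4-propylphenyl on the carbonyl carbon gives a 1.7-fold higher number from compound 2 to compound 3 (0.23 log units; within the scatter) and, set against the other aryl group, a 1.2-fold lower number from compound 1 to compound 3 (0.08 log units; within the scatter), so at this position compound 3 cannot be told apart from either compound 2 or compound 1, even though those two are separated by a 2.0-fold lower number from compound 1 to compound 2 (0.31 log units; beyond the scatter), a step that lies beyond the scatter. For the compounds shown here, the earlier pair showed only that an exchange of one methyl-bearing ring for another could produce a modest step, whereas this result shows that a ring carrying a propyl chain and no fluorine produces no step beyond the scatter from either of them, and across these three aryl groups on the amide carbonyl the numbers shift by no more than that modest step. Nothing at hand explains why these three groups behave as they do, and no measurement beyond these numbers bears on it.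

As far as these compounds go, whether an amine or a carboxylic acid on this ring would move the number further remains open. So does the effect of a chain longer than propyl at this place, and of any change to the shared core.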